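A Longer Chain on the Shared Core

The compounds below may be only part of what the source reports. "The series", "measured", "known", "first", "only" and "open" are said of these compounds alone.

In a functional assay on MCF7 cells (Homo sapiens) for antiproliferative activity, with a stated time of 5 days (on this read-out higher numbers stand for weaker inhibition and lower numbers for stronger inhibition), compound 1 (`COc1ccc(-c2[nH]c3ccc(C)cc3c2C=C(C#N)C#N)cc1`) gives 200 nM, and compound 2 (`CCCCc1ccc2[nH]c(-c3ccc(OC)cc3)c(C=C(C#N)C#N)c2c1`) gives 13 nM, the lower of the two numbers. Among the compounds with values here, only one measured step bears on the next change: a 15-fold lower number from compound 1 to compound 2 (1.19 log units; beyond the scatter), which lies beyond the scatter and places propyl in place of hydrogen on a saturated chain carbon bound to an aromatic carbon. Compound 3 (`CCCCCc1ccc2[nH]c(-c3ccc(OC)cc3)c(C=C(C#N)C#N)c2c1`) lengthens that same chain: methyl in place of hydrogen on a saturated chain carbon, four bonds along the chain from an aromatic carbon. The addition is smaller than the propyl of the step of a 15-fold lower number from compound 1 to compound 2 (1.19 log units; beyond the scatter), and that single step cannot show whether the trend continues. No change beyond the scatter is therefore expected in this assay, with any shift more likely towards a slightly lower number. The expected change is a 1.2-fold lower number from compound 2 to compound 3 (0.07 log units; within the scatter). Compound 3 is estimated at 11 nM, within an expected range of 4 nM to 30 nM.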

Compound 3, half-maximal inhibitory concentration: 76 nM
The estimate for compound 3 lay 6.9-fold (0.84 log units) below the measured number; the whole stated range lies below it.
By their numbers in this assay, from the lowest: compound 2; then compound 3; then compound 1.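

In this assay, within the data shown here, adding one methyl at the far end of the chain brings a 5.8-fold higher number from compound 2 to compound 3 (0.77 log units; beyond the scatter) and so shows that a longer chain at this position does not keep lowering the number, which the single earlier step could not show. Part of the earlier gain remains, with a 2.6-fold lower number from compound 1 to compound 3 (0.42 log units; beyond the scatter) still separating the shortest and longest chains shown, so the change in length does not act in one direction throughout this short series. Nothing available explains this reversal.

Going by these compounds, whether an ethyl or propyl chain at this position would give a number as low as that of compound 2 remains open. So does whether a still longer chain would raise the number further, or whether a chain ending in an amine or a carboxylic acid would fit the same trend.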